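Swapping an N-substituent: from compound 3 to compound 4

A few compounds are considered here, and "the series" means these few. Any claim that something is new, unique, unknown or untested is made for them only; others in the source may bear on it.

- compound 1 `Nc1ccccc1NC(=O)/C=C/c1ccc([C@H]2CN(C3COC3)C[C@@H]2C(=O)Nc2ccc(Cl)cc2)cc1`: 13 mL/min/kg
- compound 2 `CC(C)(C)N1C[C@H](C(=O)Nc2ccc(Cl)cc2)[C@@H](c2ccc(/C=C/C(=O)Nc3ccccc3N)cc2)C1`: 8 mL/min/kg
- compound 3 `CC(C)(CO)N1C[C@H](C(=O)Nc2ccc(Cl)cc2)[C@@H](c2ccc(/C=C/C(=O)Nc3ccccc3N)cc2)C1`: 12 mL/min/kg

These numbers come from an in vitro ADME assay on microsomes from liver (Homo sapiens) for pharmacokinetics, read by LC-MS, with a stated time of 10 min, tested at 1 uM; on this read-out higher numbers stand for fast clearance and lower numbers for slow clearance. There, compound 3 gives 12 mL/min/kg, and all three compounds lie within the usual scatter of one another.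

Compound 4 `CCNC(=O)N1C[C@H](C(=O)Nc2ccc(Cl)cc2)[C@@H](c2ccc(/C=C/C(=O)Nc3ccccc3N)cc2)C1` keeps the shared core but has ethylcarbamoyl in place of 1-(hydroxymethyl)-1-methylethyl on an amine nitrogen in a ring.

Three measured steps involve changes at this same place: a 1.6-fold lower number from compound 1 to compound 2 (0.21 log units; within the scatter), a 1.1-fold lower number from compound 1 to compound 3 (0.03 log units; within the scatter) and a 1.5-fold higher number from compound 2 to compound 3 (0.18 log units; within the scatter). All three stayed within the scatter, so swapping groups here has not yet moved the number measurably. Within the data shown here, none of the measured compounds carries ethylcarbamoyl, however, so these steps are only a loose guide and the range must stay wide.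

In this assay, no step beyond the scatter is expected, and the estimated change is no change at the digits printed from compound 3 to compound 4 (within the scatter). Compound 4 is expected at about 12 mL/min/kg, with an estimated range of 6 mL/min/kg to 24 mL/min/kg.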

Compound 4, clearance: 9 mL/min/kg
Compound 4: the middle estimate sits 1.3-fold (0.12 log units) above what was measured, and the stated range covers the measured number.
By their numbers in this assay, from the lowest: compounds 2, 4, 3 and 1 (each within the scatter of the next).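

In this assay, among these compounds, ethylcarbamoyl is the only one of the four groups on this amine nitrogen in a ring that carries a carbonyl, yet the number stays within the scatter of all three other compounds (a 1.3-fold lower number from compound 3 to compound 4 (0.12 log units; within the scatter); a 1.1-fold higher number from compound 2 to compound 4 (0.05 log units; within the scatter); a 1.4-fold lower number from compound 1 to compound 4 (0.16 log units; within the scatter)). The position has therefore now taken a group with a double bond outside aromatic rings, as well as the oxetan-3-yl, tert-butyl and 1-(hydroxymethyl)-1-methylethyl groups, without any measurable step in clearance. Nothing available explains why these four groups give numbers so alike.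

Still open, on these data alone, is whether any group at this nitrogen can produce a step beyond the scatter, such as a carboxylic acid, a sulfonyl group or a longer chain. The four compounds also share the (4-chlorophenyl)carbamoyl group, so they cannot show how much that part contributes.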